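The source may hold more compounds than are shown below. What is called first, only, known or untested is meant among the compounds shown, and "the series" means these compounds.

Working notes on the series. Compound 1 `Cc1nn(CC2(O)COC2)cc1Nc1nc(N)c2c(C#N)c(N3CCC[C@H]3C)n(C)c2n1` is the stronger of the two measured compounds: in an assay on isolated protein for inhibition of Leucine-rich repeat serine/threonine-protein kinase 2 variant G2019S (Homo sapiens), read by TR-FRET and LanthaScreen, with stated times of 50 min and 30 min, in the presence of a further agent that is not named here (on this read-out higher numbers stand for weaker inhibition and lower numbers for stronger inhibition), compound 1 gives 51 nM, while compound 2 `C[C@@H]1CCCN1c1c(C#N)c2c(N)nc(Nc3ccn(C)n3)cc2n1C` in the same assay gives 206 nM, a gap that lies beyond the usual scatter. Compound 2 differs from compound 1 in more than one place, so nothing can be read from that pair about any single change.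

Compound 3 `Cc1nn(C)cc1Nc1nc(N)c2c(C#N)c(N3CCC[C@H]3C)n(C)c2n1` is the next compound to be measured. It differs from compound 1 by one change: hydrogen in place of 3-hydroxyoxetan-3-yl on a saturated chain carbon bound to an aromatic nitrogen. Among the measured compounds shown here, no measured pair isolates this change, so the expectation rests on compound 1 alone. The step from compound 1 to compound 3 is expected to be small and, if anything, toward weaker inhibition, a 1.6-fold higher number from compound 1 to compound 3 (0.20 log units; within the scatter), with a fair chance of no step beyond the scatter. Compound 3 is therefore estimated at 80 nM, in a range from 30 nM to 220 nM.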

Compound 3, half-maximal inhibitory concentration: 30 nM
Beside the measured number, compound 3's estimate is 2.7-fold (0.43 log units) above it; low and high end bracket the measured number.
By their numbers in this assay, from the lowest: compounds 3 and 1 (each within the scatter of the next); then compound 2.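

Hydrogen in place of 3-hydroxyoxetan-3-yl on a saturated chain carbon bound to an aromatic nitrogen gives a 1.7-fold lower number from compound 1 to compound 3 (0.23 log units; within the scatter) in this assay, so compound 1 and compound 3 cannot be told apart on this read-out. This place on the shared core therefore carries either the small methyl or the much larger (3-hydroxyoxetan-3-yl)methyl with no step beyond the scatter, and the 3-hydroxyoxetan-3-yl group is not required to keep inhibition at this level. No measurement offered here accounts for this result.

From the compounds shown here alone, whether an amine, a carboxylic acid or a longer chain at this place would also stay within the scatter remains open. Compound 2 differs from the others in more than one place, so it cannot show whether the same holds with a different group on the other side of the core.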